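The compounds below may be only part of what the source reports. "The series", "measured", "known", "first", "only" and "open" are said of these compounds alone.

Working notes on the urea-acrylamide series.

Two compounds carry the shared core with the 4-chloro-3-(trifluoromethyl)phenyl urea. Compound 1 `O=C(/C=C/c1ccc(NC(=O)Nc2ccc(Cl)c(C(F)(F)F)c2)cc1)NC1CCC1` gives 15400 nM in a functional assay on A-375 cells (Homo sapiens) for inhibition, read by MTT assay, with a stated time of 120 h; a lower number here means a stronger inhibitor, a higher number a weaker inhibitor. Compound 2 `CC(NC(=O)/C=C/c1ccc(NC(=O)Nc2ccc(Cl)c(C(F)(F)F)c2)cc1)c1ccccc1` gives 20800 nM in this assay. Within the data shown here, the single measured step, a 1.4-fold higher number from compound 1 to compound 2 (0.13 log units; within the scatter), concerns the group on the acrylamide nitrogen, so compound 2 stands with compound 1 at numbers that cannot be told apart.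

Compound 3 `CC(NC(=O)/C=C/c1ccc(NC(=O)Nc2cc(C(F)(F)F)ccc2Cl)cc1)c1ccccc1` is not yet measured. It differs from compound 2 only on the urea side: 2-chloro-5-(trifluoromethyl)phenyl in place of 4-chloro-3-(trifluoromethyl)phenyl on an amide-type nitrogen. Among the measured compounds shown here, nothing measured bears on this change; the one step in hand, from compound 1 to compound 2, alters a different part of the molecule and is itself within the scatter. No direction can therefore be read from the series for this assay, and the working expectation is no step beyond the scatter, with a wide range to allow for either direction.

For compound 3 the estimate in this assay is 25000 nM, within 8000 nM to 80000 nM. This expected step, a 1.2-fold higher number from compound 2 to compound 3 (0.08 log units; within the scatter), is what the series supports until the measurement arrives.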

Compound 3, half-maximal inhibitory concentration: 40900 nM
For compound 3 the middle estimate is 1.6-fold (0.21 log units) below the measured one; the range from low to high includes it.
By their numbers in this assay, from the lowest: compounds 1, 2 and 3 (each within the scatter of the next, the first and the last beyond it).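

Among these compounds, this is the first measured change on the urea side of the series: in this assay, 2-chloro-5-(trifluoromethyl)phenyl in place of 4-chloro-3-(trifluoromethyl)phenyl on an amide-type nitrogen gives a 2.0-fold higher number from compound 2 to compound 3 (0.29 log units; within the scatter) and so stays within the scatter, though at the far end of it. The two groups have the same atoms, and in this pair their different arrangement does not separate compound 2 and compound 3 in this assay, so this one step gives no firm preference for either group on the 1-phenylethyl amide. No accompanying data bear on why the step has this size.

Going by these compounds, whether the same exchange gives a comparable step with cyclobutyl on the acrylamide nitrogen remains open, since only the 1-phenylethyl pair can be read here. Also open, on these data alone, is whether a group of a different kind on the urea nitrogen, such as an unsubstituted phenyl, a pyridine ring or a phenyl carrying a carboxylic acid, would give a step beyond the scatter from compound 2 in this assay.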